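The source may report more compounds than this note shows. Statements on the series, on what has been measured and on what is new or still open speak of the compounds shown alone.

Measured in an ADME assay on MCF-10A cells (Homo sapiens) for cytotoxicity, read by MTT assay, with a stated time of 72 h; a higher number here means a weaker inhibitor, a lower number a stronger inhibitor:
compound 1, `Cc1ccc(-c2ccc(C)n2-c2ccc(-c3nc4ccccc4s3)cc2)cc1`, 30600 nM
compound 2, `COc1ccc(-c2ccc(C)n2-c2ccc(-c3nc4ccccc4s3)cc2)cc1`, 36300 nM
compound 3, `Cc1ccc(-c2ccc(C)n2-c2ccc(-c3nc4ccc(F)cc4s3)cc2)cc1`, 33600 nM

Among these three numbers compound 3 sits second highest, but its neighbours lie within the scatter on either side: compound 2 reads slightly higher and compound 1 slightly lower, so no order among the three can be claimed. The step already seen in this series, a 1.1-fold higher number from compound 1 to compound 3 (0.04 log units; within the scatter), is flat, and the same holds for a 1.2-fold higher number from compound 1 to compound 2 (0.07 log units; within the scatter).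

Compound 4, `COc1ccc(-c2ccc(C)n2-c2ccc(-c3nc4ccc(F)cc4s3)cc2)cc1`, is not yet measured. It differs from compound 3 in one place: methoxy in place of methyl on an aromatic carbon. Among the compounds with values here, the single measured step that bears on this change is a 1.2-fold higher number from compound 1 to compound 2 (0.07 log units; within the scatter), made on the core lacking the fluoro group, and it stayed within the scatter. The step to compound 4 is therefore expected to be of the same kind, a 1.2-fold higher number from compound 3 to compound 4 (0.06 log units; within the scatter), with no movement beyond the scatter in either direction.

For compound 4 the estimate is 39000 nM, with a range from 20000 nM to 78000 nM.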

Compound 4, half-maximal inhibitory concentration: 37800 nM
The estimate for compound 4 lay 1.0-fold (0.01 log units) above the measured number; the range from low to high includes it.
By their numbers in this assay, from the lowest: compounds 1, 3, 2 and 4 (each within the scatter of the next).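

In this assay, exchanging 4-methylphenyl for 4-methoxyphenyl on the fluoro-bearing core gives a 1.1-fold higher number from compound 3 to compound 4 (0.05 log units; within the scatter), so the flat result at this position no longer rests on one core alone: the same change on two cores in this assay, a 1.2-fold higher number (0.07 log units; within the scatter) from compound 1 to compound 2 and a 1.1-fold higher number (0.05 log units; within the scatter) from compound 3 to compound 4, 1.1-fold (0.02 log units) apart, within the scatter of two such steps. Within the data shown here, the fluoro change, earlier seen only with the methyl group present, is also flat with the methoxy group present, at a 1.0-fold higher number from compound 2 to compound 4 (0.02 log units; within the scatter): the same change on two cores in this assay, a 1.1-fold higher number (0.04 log units; within the scatter) from compound 1 to compound 3 and a 1.0-fold higher number (0.02 log units; within the scatter) from compound 2 to compound 4, 1.1-fold (0.02 log units) apart, within the scatter of two such steps. Together, the four compounds form a closed square of single changes in which neither change shifts the number beyond the scatter, whichever core carries it.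

The compounds shown carry only methyl or methoxy at this position, and only hydrogen or fluoro at the second site. As far as these compounds go, whether an amine or a carboxylic acid at this position would move the number in this assay beyond the scatter remains open.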